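Trifluoromethylphenyl Swap Tested on the Trimethoxyphenyl Core

This account rests on a few compounds, and the source may have more. Where it says the series, first, only, none or still open, it means among the compounds named here.

Compound 2 `Cc1ccc(Nc2nc(SCc3cn(CC(=O)NC(=O)Nc4ccccn4)nn3)nc(-c3ccc(C(C)C)cc3)c2C#N)cc1` carries a 4-isopropylphenyl group and a (4-methylphenyl)amino group on the shared core. In a functional assay on MGC-803 cells (Homo sapiens) for inhibition, read by MTT assay, with a stated time of 72 h (a lower number here means a stronger inhibitor, a higher number a weaker inhibitor), compound 2 gives 3360 nM. Compound 1 `CC(C)c1ccc(-c2nc(SCc3cn(CC(=O)NC(=O)Nc4ccccn4)nn3)nc(Nc3cccc(C(F)(F)F)c3)c2C#N)cc1` differs from it by 3-(trifluoromethyl)phenyl in place of 4-methylphenyl on a nitrogen on an aromatic ring. In this assay compound 1 reaches only a limit, > 64000 nM, the limit described by the limit of > 64000 nM in this assay, at which 1 of the 3 values shown sits. That change thus made an at least 19-fold higher number from compound 2 to compound 1 (1.27 log units; beyond the scatter). Compound 3 `COc1cc(-c2nc(SCc3cn(CC(=O)NC(=O)Nc4ccccn4)nn3)nc(Nc3ccc(C)cc3)c2C#N)cc(OC)c1OC` differs from compound 2 in the core, by 3,4,5-trimethoxyphenyl in place of 4-isopropylphenyl on an aromatic carbon; in this assay compound 3 gives 7030 nM, a shift of a 2.1-fold higher number from compound 2 to compound 3 (0.32 log units; beyond the scatter).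

Compound 4 `COc1cc(-c2nc(SCc3cn(CC(=O)NC(=O)Nc4ccccn4)nn3)nc(Nc3cccc(C(F)(F)F)c3)c2C#N)cc(OC)c1OC` has not yet been measured. It stands to compound 3 as compound 1 stands to compound 2: 3-(trifluoromethyl)phenyl in place of 4-methylphenyl on a nitrogen on an aromatic ring, the same change at the same place, and among the compounds shown it occurs twice in all. The earlier step, an at least 19-fold higher number from compound 2 to compound 1 (1.27 log units; beyond the scatter), ran from compound 2 all the way to the limit of this assay. Compound 3 begins from a higher number, 7030 nM, than compound 2 did. For compound 4 the step is therefore expected to be a 13-fold higher number from compound 3 to compound 4 (1.11 log units; beyond the scatter). Compound 4 is estimated at 90000 nM, expected to lie between 25000 nM and 300000 nM, with a real chance that this assay again reports only a limit rather than a number.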

Compound 4, half-maximal inhibitory concentration: 8210 nM
Compound 4: middle estimate off by 11-fold (1.04 log units), on the high side, and the stated range ends above it.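

On the core of compound 3, the change from 4-methylphenyl to 3-(trifluoromethyl)phenyl gave a 1.2-fold higher number from compound 3 to compound 4 (0.07 log units; within the scatter) in this assay, so the large loss seen on the core of compound 2 did not carry over, and the two steps differ: the same change on two cores in this assay, an at least 19-fold higher number (1.27 log units; beyond the scatter) from compound 2 to compound 1 and a 1.2-fold higher number (0.07 log units; within the scatter) from compound 3 to compound 4, at least 16-fold (1.21 log units) apart, beyond the scatter of two such steps

The change of the other group, 3,4,5-trimethoxyphenyl in place of 4-isopropylphenyl, likewise depended on its partner, giving an at least 7.7-fold lower number from compound 1 to compound 4 (0.89 log units; beyond the scatter) and running the opposite way to the step it was set against: the same change on two cores in this assay, a 2.1-fold higher number (0.32 log units; beyond the scatter) from compound 2 to compound 3 and an at least 7.7-fold lower number (0.89 log units; beyond the scatter) from compound 1 to compound 4, at least 16-fold (1.21 log units) apart, beyond the scatter of two such steps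

On these data alone, compound 1 gives > 64000 nM, which is a limit and not a number, so the true size of the earlier step stays unknown, and these four compounds do not show why the change behaves differently on the two cores or how it would behave on a third.

The compounds shown leave open whether this dependence holds for other groups on the nitrogen, such as a phenyl ring carrying a chlorine atom or a carboxylic acid. They also leave open whether it survives when the nitrile of the shared core gives way to an amide or when the aromatic carbon carries a simple unsubstituted phenyl group.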